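From hydroxyethyl to trifluoromethyl on the chain double bond

A few compounds are considered here, and "the series" means these few. Any claim that something is new, unique, unknown or untested is made for them only; others in the source may bear on it.

Compound 1 `CCC/C(=C(/c1ccc(/C=C/C(=O)O)cc1)c1ccc2[nH]ncc2c1)c1ccccc1` gives 11 nM in a functional assay on MCF7 cells (Homo sapiens) for cytotoxicity, read by CellTiter-Glo, with a stated time of 5 days; a higher number here means a weaker inhibitor, a lower number a stronger inhibitor. Compound 2 `O=C(O)/C=C/c1ccc(/C(=C(/CCO)c2ccccc2)c2ccc3[nH]ncc3c2)cc1` reaches only a limit of the assay, > 1000 nM. The step of an at least 90-fold higher number from compound 1 to compound 2 (1.95 log units; beyond the scatter) thus ends at the limit of > 1000 nM in this assay, at which 1 of the 2 values shown sits. Compound 3 `O=C(O)/C=C/c1ccc(/C(=C(\c2ccccc2)C(F)(F)F)c2ccc3[nH]ncc3c2)cc1` differs from compound 2 by trifluoromethyl in place of 2-hydroxyethyl on a double-bonded chain carbon bound to an aromatic carbon and a double-bonded chain carbon. Of the measured steps only an at least 90-fold higher number from compound 1 to compound 2 (1.95 log units; beyond the scatter) bears on this change, and it was large, so a step back toward lower numbers is expected in this assay, its size uncertain since compound 2 carries only a limit. The expected step is an at least 10-fold lower number from compound 2 to compound 3 (1.00 log units; beyond the scatter). Compound 3 is estimated at 100 nM, between 20 nM and 1000 nM.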

Compound 3, half-maximal inhibitory concentration: 5.5 nM
Estimate against measurement, compound 3: 18-fold (1.26 log units) above; measured number below the stated range.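

In this assay, trifluoromethyl on this double-bonded chain carbon gives an at least 180-fold lower number from compound 2 to compound 3 (2.25 log units; beyond the scatter), so the loss seen with 2-hydroxyethyl does not extend to every replacement of propyl here. Set against propyl, trifluoromethyl gives a 2.0-fold lower number from compound 1 to compound 3 (0.30 log units; within the scatter), and the two groups are not separated at this position. Compound 2 is only a limit of the assay, so the large step has a bound and no exact size: the limit of > 1000 nM in this assay, at which 1 of the 3 values shown sits.

On these data alone, whether an amine, a carboxylic acid or a longer chain such as butyl would be tolerated on this carbon stays open. So does whether the hydroxy of compound 2 alone accounts for its loss, which a methoxyethyl group could test.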